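Methoxy count on the aryl-pyrazole and SNB-19 cytotoxicity

A few compounds are considered here, and "the series" means these few. Any claim that something is new, unique, unknown or untested is made for them only; others in the source may bear on it.

Measured compounds:
compound 1 `COc1ccc(-c2cc(/C=C/C(=O)c3ccc(N)cc3)[nH]n2)cc1`: 75%
compound 2 `COc1cc(-c2cc(/C=C/C(=O)c3ccc(N)cc3)[nH]n2)cc(OC)c1OC`: 79%
compound 3 `COc1ccc(C(=O)/C=C/c2cc(-c3cc(OC)c(OC)c(OC)c3)n[nH]2)cc1OC`: 73%

In a functional assay on SNB-19 cells (Homo sapiens) for cytotoxicity, read by sulforhodamine B assay, with a stated time of 48 h, tested at 1 uM (on this read-out higher numbers stand for a weaker effect at the one concentration tested and lower numbers for a stronger effect), compound 2 gives the highest of the three numbers, though compound 1 and compound 3 both lie within the scatter of it. Among the measured compounds shown here, the one step that differs in a single place, a number 6 percentage points lower from compound 2 to compound 3 (within the scatter), changes the aryl on the carbonyl and so does not touch the place altered here. Compound 4 `COc1ccc(-c2cc(/C=C/C(=O)c3ccc(N)cc3)[nH]n2)cc1OC` differs from compound 2 by hydrogen in place of methoxy on an aromatic carbon. Compound 1 and compound 2 differ at the same ring, and their two values lie within the scatter of each other. For the measured compounds named here, no measured step therefore points to a shift beyond the scatter, and for compound 4 a step of a number 2 percentage points lower from compound 2 to compound 4 (within the scatter) is expected, giving an estimated 77% within 67% to 87%.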

Compound 4, a percentage reported as activity, at one concentration (the size of the read-out at that concentration, not a potency): 84%
Compound 4: the middle estimate sits 7 percentage points below what was measured; the range from low to high includes it.
By their numbers in this assay, from the lowest: compounds 3, 1, 2 and 4 (each within the scatter of the next, the first and the last beyond it).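

In this assay, at this aromatic carbon, hydrogen in place of methoxy gives a number 5 percentage points higher from compound 2 to compound 4 (within the scatter), and on the same ring methoxy in place of hydrogen gives a number 9 percentage points higher from compound 1 to compound 4 (within the scatter) in this single-place pair. This ring now has two single-place methoxy steps, and both lie within the scatter, so neither shows a measurable effect of that group on this read-out. Nothing shown bears on why these numbers fall as they do. Still open, on these data alone, is whether a hydroxyl group, a fluorine atom or an amine at this aromatic carbon would give a step beyond the scatter.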